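Methyl to Ethyl on the Ring Nitrogen: Expected Cytotoxicity

The compounds below may be only part of what the source reports. "The series", "measured", "known", "first", "only" and "open" are said of these compounds alone.

Compound 1, `Cc1cc2c(c(=O)[nH]1)C(c1cn([C@H]3C[C@H](O)[C@@H](CO)O3)c(=O)[nH]c1=O)C(C#N)=C(N)O2`, gives > 100000 nM in an ADME assay on HEL cells (Homo sapiens) for cytotoxicity, read by microscopy; on this read-out lower numbers stand for higher toxicity in this test and higher numbers for lower toxicity in this test.
Compound 2, `Cc1cc2c(c(=O)n1C)C(c1cn([C@H]3C[C@H](O)[C@@H](CO)O3)c(=O)[nH]c1=O)C(C#N)=C(N)O2`, gives > 100000 nM in this assay.
Compound 3, `Cc1cc2c(c(=O)o1)C(c1cn([C@H]3C[C@H](O)[C@@H](CO)O3)c(=O)[nH]c1=O)C(C#N)=C(N)O2`, gives > 100000 nM in this assay.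

Each of these values is a limit of the assay, not a measured number. Compound 2 therefore stands only at a limit, and the same holds for the two other values, which all sit at the limit of > 100000 nM in this assay, at which 3 of the 3 values shown sit. Going by the values given here, the one step between measured compounds that differ in a single place, a step that the two limits leave unreadable from compound 1 to compound 2, is unreadable, since both of its ends are limits.

Compound 4, `CCn1c(C)cc2c(c1=O)C(c1cn([C@H]3C[C@H](O)[C@@H](CO)O3)c(=O)[nH]c1=O)C(C#N)=C(N)O2`, differs from compound 2 by methyl in place of hydrogen on a saturated chain carbon bound to an aromatic nitrogen. Among the compounds with values here, no measured step bears on this change, and the one step that has been measured gives no readable size. Because all three values sit at the limit of > 100000 nM in this assay, at which 3 of the 3 values shown sit, no step beyond the scatter can be read from the data, and the expectation is a step of none beyond the scatter. The step of a number no higher from compound 2 to compound 4 (the limit leaves the size open) is thus expected to be essentially flat. Compound 4 is estimated at 100000 nM, with a range from 40000 nM to 300000 nM, most likely again reported only as a limit.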

Compound 4, minimum cytotoxic concentration: > 100000 nM
Compound 4: only a limit was reported; the forecaster's own chance of this, stated with the estimate: 85%; the middle value sits exactly at the limit.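

In this assay compound 4 gives > 100000 nM, a limit and not a number. No step from compound 1 or compound 2 to compound 4 can be read, and every value shown is a limit: the limit of > 100000 nM in this assay, at which 4 of the 4 values shown sit.

The compounds shown leave open whether changing the group on the aromatic nitrogen alters toxicity to these cells, and at what concentration any of them would become toxic.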